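From methoxy to fluoro: compound 3 to compound 4

The compounds below may be only part of what the source reports. "The series", "measured", "known", "first", "only" and "open" are said of these compounds alone.

In a functional assay on HL-60 cells (Homo sapiens) for cytotoxicity, read by MTT assay, with a stated time of 72 h (a lower number here means a stronger inhibitor, a higher number a weaker inhibitor), compound 3 (`COc1ccc(S(=O)(=O)c2nc3ccccc3nc2N2CCC(O)CC2)cc1`) gives 3230 nM. Compound 2 (`O=S(=O)(c1ccccc1)c1nc2ccccc2nc1N1CCC(O)CC1`) gives 2900 nM, and compound 1 (`O=S(=O)(c1ccc(F)cc1)c1nc2ccccc2nc1N1CCCC(O)C1`) gives 2620 nM. Compound 3 therefore lies within the scatter of both others, and these numbers cannot be ranked.

Compound 4 (`O=S(=O)(c1ccc(F)cc1)c1nc2ccccc2nc1N1CCC(O)CC1`) has not yet been measured. It has fluoro in place of methoxy on an aromatic carbon. Among the measured compounds shown here, the only measured step that bears directly on this change is a 1.1-fold higher number from compound 2 to compound 3 (0.05 log units; within the scatter). That step put methoxy in place of hydrogen on an aromatic carbon and stayed within the scatter. Differing from compound 4 elsewhere in the structure, compound 1 already carries the 4-fluorophenyl group and reads 2620 nM.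

Neither observation gives grounds to expect a real shift in this assay. The expected change is a 1.1-fold lower number from compound 3 to compound 4 (0.05 log units; within the scatter), which would stay within the scatter. For compound 4 the estimated value is 2900 nM, with an expected range from 1500 nM to 5500 nM.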

Compound 4, half-maximal inhibitory concentration: 1450 nM
Beside the measured number, compound 4's estimate is 2.0-fold (0.30 log units) above it; measured number below the stated range.
By their numbers in this assay, from the lowest: compounds 4, 1, 2 and 3 (each within the scatter of the next, the first and the last beyond it).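

In this assay, among the compounds shown here, the change from 4-methoxyphenyl to 4-fluorophenyl gives a 2.2-fold lower number from compound 3 to compound 4 (0.35 log units; beyond the scatter) as the only step in this set that lies beyond the scatter, and it is a modest one. Fluoro in place of hydrogen gives a 2.0-fold lower number from compound 2 to compound 4 (0.30 log units; within the scatter) and 4-hydroxypiperidin-1-yl in place of 3-hydroxypiperidin-1-yl gives a 1.8-fold lower number from compound 1 to compound 4 (0.26 log units; within the scatter) and both stay within the scatter, so neither can be read as a real change. The group at this position can therefore matter, but only fluoro and methoxy separate clearly, while hydrogen lies within the scatter of both.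

On these data alone, whether an amine or a carboxylic acid at this position would separate from hydrogen remains open. Nothing measured here bears on why fluoro and methoxy differ.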